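Swapping the benzyl ether arm on two related cores

The source may hold more compounds than are shown below. What is called first, only, known or untested is meant among the compounds shown, and "the series" means these compounds.

The series is built around two cores that carry a benzyloxy-substituted aryl arm. Compound 1 `Cc1ccc(NC(=S)NC(=O)c2ccc(OCc3cccc(C(F)(F)F)c3)cc2)cc1-c1nc2ccccc2[nH]1` and compound 2 `Cc1ccc(NC(=S)NC(=O)c2ccc(OCc3ccccc3F)cc2)cc1-c1nc2ccccc2[nH]1` share one core, while compound 3 `Cc1ccc(NC(=O)NC(=O)c2ccc(OCc3cccc(C(F)(F)F)c3)cc2)cc1-c1nc2ccccc2[nH]1` and compound 4 `Cc1ccc(NC(=O)NC(=O)c2ccc(OCc3ccccc3F)cc2)cc1-c1nc2ccccc2[nH]1` share the other; the difference between the two cores is not broken down here.

In a functional assay on MNK45 cells (Homo sapiens) for inhibition, read by MTT assay, with a stated time of 48 h (on this read-out lower numbers stand for stronger inhibition and higher numbers for weaker inhibition), compound 1 gives 6050 nM. Compound 2, which carries 2-fluorophenyl in place of 3-(trifluoromethyl)phenyl on a saturated chain carbon bound to an oxygen on an aromatic ring, gives 2420 nM in this assay. That single change produced a 2.5-fold lower number from compound 1 to compound 2 (0.40 log units; beyond the scatter). On the second core, compound 3 gives 9600 nM in this assay, a number that sits within the usual scatter of the value for compound 1, so no order between those two can be read from these data.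

Compound 4 carries the same change relative to compound 3, namely (2-fluorophenyl in place of 3-(trifluoromethyl)phenyl on a saturated chain carbon bound to an oxygen on an aromatic ring), and has not yet been measured. Its expected outcome rests on a single precedent, the pair of compound 1 and compound 2, so the estimate is weakly founded. On that basis, compound 4 is expected to show a 2.4-fold lower number from compound 3 to compound 4 (0.38 log units; beyond the scatter) in this assay, close to the earlier step, because that precedent gave a 2.5-fold lower number from compound 1 to compound 2 (0.40 log units; beyond the scatter). Compound 4 is therefore estimated at 4000 nM in this assay, with the plausible range running from 1800 nM to 9000 nM.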

Compound 4, half-maximal inhibitory concentration: 1830 nM
Compound 4: the middle estimate sits 2.2-fold (0.34 log units) above what was measured; the range from low to high includes it.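

On the core of compound 3, putting 2-fluorophenyl in place of 3-(trifluoromethyl)phenyl gave a 5.2-fold lower number from compound 3 to compound 4 (0.72 log units; beyond the scatter) in this assay, so the number fell on both cores. The second step looks larger than the first, yet the two cannot be told apart, and the change carried over from one core to the other with no measurable difference in size: the same change on two cores in this assay, a 2.5-fold lower number (0.40 log units; beyond the scatter) from compound 1 to compound 2 and a 5.2-fold lower number (0.72 log units; beyond the scatter) from compound 3 to compound 4, 2.1-fold (0.32 log units) apart, within the scatter of two such steps This rests on only two matched pairs, a single change and a single assay, so it shows agreement among these four compounds but no general rule for the series, and it gives no explanation of why the number falls.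

The swap alters both the substituent and its place on the ring, and the compounds shown do not separate those two contributions. As far as these compounds go, how an unsubstituted benzyl group, a methoxybenzyl group or a chlorobenzyl group would compare on either core remains open, as does the effect of a longer chain between the ether oxygen and the ring.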